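The source may report more compounds than this note shows. Statements on the series, on what has been measured and on what is new or still open speak of the compounds shown alone.

Three compounds measured in an assay for inhibition of sodium channel protein type 9 subunit alpha (Mus musculus), read by patch clamp (on this read-out higher numbers stand for weaker inhibition and lower numbers for stronger inhibition), sit close together. Compound 1 `CC(C)COc1ncc(-c2cn(C)c3cc(C(=O)NS(C)(=O)=O)ccc23)cc1Cl` gives 11 nM in this assay, compound 2 `CC(C)COc1ncc(-c2nn(C)c3cc(C(=O)NS(C)(=O)=O)ccc23)cc1Cl` gives 12 nM, and compound 3 `CC(C)COc1ccc(-c2cn(C)c3cc(C(=O)NS(C)(=O)=O)c(F)cc23)cn1` gives 14 nM. Compound 3 has the highest of the three numbers, but its gap to compound 2 and its gap to compound 1 both lie within the usual scatter of repeated measurements, so no order among the three can be read from these values.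

Compound 4 `CC(C)COc1ccc(-c2cn(C)c3cc(C(=O)NS(=O)(=O)C4CC4)c(F)cc23)cn1` is not yet measured. Against compound 3 it shows one change: cyclopropyl in place of methyl on a sulfonyl sulfur. Among the measured compounds shown here, nothing among the measured compounds tests this exchange, since compounds 1, 2 and 3 all carry the methyl on the sulfonyl sulfur. For the measured compounds named here, with no step of this kind to lean on, the step from compound 3 to compound 4 in this assay is expected to be small, most likely within the scatter, and in no clear direction, so the estimate is no change at the digits printed from compound 3 to compound 4 (within the scatter). Compound 4 is therefore expected to give about 14 nM in this assay, with a range from 5 nM to 40 nM.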

Compound 4, half-maximal inhibitory concentration: 24 nM
The estimate for compound 4 lay 1.7-fold (0.23 log units) below the measured number; measured number inside the range.
By their numbers in this assay, from the lowest: compounds 1, 2, 3 and 4 (each within the scatter of the next, the first and the last beyond it).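

Among the compounds shown here, compound 4 gives the first reading of this exchange: in this assay, cyclopropyl in place of methyl on a sulfonyl sulfur gives a 1.7-fold higher number from compound 3 to compound 4 (0.23 log units; within the scatter), so no real difference between the two groups can be claimed at this place. The methyl is therefore not needed to hold the reading in the same range, since compound 4, with its three carbons and three-membered ring on the sulfonyl sulfur, stands at 24 nM in this assay. No information is available to explain this result.

As far as these compounds go, whether a longer chain such as n-butyl, a phenyl ring or a dimethylamino group would be accepted on the same sulfonyl sulfur remains open. From the compounds shown here alone, it is equally open whether the exchange would read the same on the cores of compound 1 and compound 2, as this single pair shares the core of compound 3.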